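This account rests on a few compounds, and the source may have more. Where it says the series, first, only, none or still open, it means among the compounds named here.

In an in vitro assay on Sf21 cells for inhibition of high affinity 3',5'-cyclic-AMP phosphodiesterase 7A (Homo sapiens), read by scintillation proximity assay, with a stated time of 30 min (a lower number here means a stronger inhibitor, a higher number a weaker inhibitor), compound 1 `CC(=O)Nc1ccc(NC(=O)c2cn(Cc3c(F)cccc3F)c3ccc(=O)[nH]c3c2=O)cc1` gives 24 nM, and compound 2 `CC(=O)Nc1ccc(NC(=O)c2cn(Cc3c(F)cccc3Cl)c3ccc(=O)[nH]c3c2=O)cc1` gives 17 nM; the difference is a 1.4-fold lower number from compound 1 to compound 2 (0.15 log units; within the scatter). For the measured compounds named here, compound 2 therefore sits within the scatter of the only other number measured, that of compound 1, and no ranking follows. Compound 3 `COc1ccc(NC(=O)c2cn(Cc3c(F)cccc3Cl)c3ccc(=O)[nH]c3c2=O)cc1Cl` differs from compound 2 by 3-chloro-4-methoxyphenyl in place of 4-acetamidophenyl on an amide-type nitrogen. Going by the values given here, no measured step touches this position; the single step measured, a 1.4-fold lower number from compound 1 to compound 2 (0.15 log units; within the scatter), concerns a halogen elsewhere on the shared core and gives no guidance. The expected step is therefore a 1.5-fold higher number from compound 2 to compound 3 (0.17 log units; within the scatter), without direction beyond the scatter. Compound 3 is expected to give 25 nM, between 6 nM and 100 nM.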

Compound 3, half-maximal inhibitory concentration: 34 nM
Estimate against measurement, compound 3: 1.4-fold (0.13 log units) below, within the range that was stated.
By their numbers in this assay, from the lowest: compounds 2, 1 and 3 (each within the scatter of the next).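

In this assay the whole aryl group on the amide-type nitrogen was exchanged, with a 2.0-fold higher number from compound 2 to compound 3 (0.30 log units; within the scatter) as the result. A group with 0 hydrogen-bond donors, 3-chloro-4-methoxyphenyl, therefore reads within the scatter of 4-acetamidophenyl, so in this pair the acetamide is not required for a number in this range.

Chloro and methoxy enter together, so their separate contributions remain open, as does the reading of a carboxylic acid or a morpholine on this phenyl ring. Nothing available explains why the two groups read alike.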